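Swapping sulfamoyl for bromo on compound 1

The source may report more compounds than this note shows. Statements on the series, on what has been measured and on what is new or still open speak of the compounds shown alone.

Compound 1 `Cc1cc(C)cc(S(=O)(=O)n2c(SCC(=O)Nc3ccccc3S(N)(=O)=O)nc3ccccc32)c1`: 25000 nM
Compound 2 `Cc1cc(C)cc(S(=O)(=O)n2c(OCC(=O)Nc3ccccc3Cl)nc3ccccc32)c1`: 169000 nM
Compound 3 `Cc1cc(C)cc(S(=O)(=O)n2c(OCC(=O)Nc3ccc(S(N)(=O)=O)cc3Cl)nc3ccccc32)c1`: > 227000 nM (a limit of the assay, not a number)

In an ADME assay on MT4 cells (Homo sapiens) for cytotoxicity, read by MTT assay, with a stated time of 5 days (on this read-out lower numbers stand for higher toxicity in this test and higher numbers for lower toxicity in this test), compound 1 gives 25000 nM, the lower of the two actual numbers, and compound 2 gives 169000 nM. Compound 4 `Cc1cc(C)cc(S(=O)(=O)n2c(SCC(=O)Nc3ccccc3Br)nc3ccccc32)c1` differs from compound 1 by bromo in place of sulfamoyl on an aromatic carbon, ortho to a large group (bromo in place of sulfamoyl on an aromatic carbon). Among the measured compounds shown here, the only measured step involving sulfamoyl is an at least 1.3-fold higher number from compound 2 to compound 3 (0.12 log units; that floor lies within the scatter), and it adds that group in place of hydrogen, so it fixes no size for this change. Compound 2 also lacks sulfamoyl and gives 169000 nM, but it differs from compound 1 elsewhere too, so only a moderate rise is expected in this assay. The expected step is a 1.8-fold higher number from compound 1 to compound 4 (0.26 log units; within the scatter). For compound 4 the estimated value is 45000 nM, with an expected range from 12000 nM to 170000 nM.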

Compound 4, half-maximal cytotoxic concentration: >= 235000 nM
Compound 4 ended at the assay's limit (the forecaster's own chance of this, stated with the estimate: 25%); middle value at least 5.2-fold (0.71 log units) away from the limit.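

In this assay, bromo in place of sulfamoyl on an aromatic carbon, ortho to a large group, gives an at least 9.4-fold higher number from compound 1 to compound 4 (0.97 log units; beyond the scatter). Among the compounds shown here, the only earlier step involving sulfamoyl, an at least 1.3-fold higher number from compound 2 to compound 3 (0.12 log units; that floor lies within the scatter), replaced hydrogen and stayed within the scatter, whereas this exchange moves beyond it, with sulfamoyl on the side of the lower number. The figure for compound 4 is a limit of the assay, not a number: the limit of >= 235000 nM in this assay, at which 1 of the 4 values shown sits.

Going by these compounds, the full size of this step remains open. So does whether an amine or a carboxylic acid at this position would also give a higher number than sulfamoyl.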